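This account rests on a few compounds, and the source may have more. Where it says the series, first, only, none or still open, it means among the compounds named here.

For the measured compounds named here, compound 2 `OC[C@@H]1[C@@H](O)[C@H](O)[C@@H](O)CN1CCCCCOCc1ccc(-c2ccccc2F)cc1` gives 2 nM in an assay on isolated protein for inhibition of Beta-glucosidase (Homo sapiens) (a lower number here means a stronger inhibitor, a higher number a weaker inhibitor), the lower of the two numbers measured so far. Going by the values given here, its one neighbour is compound 1 `COc1ccc(-c2ccc(COCCCCCN3C[C@H](O)[C@@H](O)[C@H](O)[C@H]3CO)cc2)cc1`, which in this assay gives 10 nM; the change from compound 1 to compound 2 brought a 5.0-fold lower number from compound 1 to compound 2 (0.70 log units; beyond the scatter), a change on the terminal aryl ring. Compound 3 `OC[C@@H]1[C@@H](O)[C@H](O)[C@@H](O)CN1CCCCCOCc1ccc(-c2ccc3c(c2)OCCO3)cc1` carries the change (2,3-dihydro-1,4-benzodioxin-6-yl in place of 2-fluorophenyl on an aromatic carbon), again on that terminal ring. Among the compounds with values here, the only measured step that bears on it is a 5.0-fold lower number from compound 1 to compound 2 (0.70 log units; beyond the scatter), which shows that swapping the terminal aryl group shifts this assay by a modest amount, and that a ring bearing oxygen acceptors sat on the weaker side. A modest rise is therefore expected for compound 3, of about a 3.0-fold higher number from compound 2 to compound 3 (0.48 log units; beyond the scatter). For compound 3 the estimated value in this assay is 6 nM, with a plausible range from 2 nM to 20 nM.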

Compound 3, half-maximal inhibitory concentration: 30 nM
Compound 3: middle estimate off by 5.0-fold (0.70 log units), on the low side; the measured number lies above the stated range.
By their numbers in this assay, from the lowest: compound 2; then compound 1; then compound 3.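

The 2,3-dihydro-1,4-benzodioxin-6-yl group makes compound 3 the weakest of the three in this assay: the swap brings a 15-fold higher number from compound 2 to compound 3 (1.18 log units; beyond the scatter), so this position can move the number further than the first step showed. The fused ring also falls short of the open 4-methoxyphenyl group, with a 3.0-fold higher number from compound 1 to compound 3 (0.48 log units; beyond the scatter), so among these compounds both oxygen-bearing groups sit on the weaker side of 2-fluorophenyl, and the fused ring sits furthest from it. No measurement at hand explains this order.

The compounds shown leave open whether the low number of compound 2 goes with its fluorine or simply with a terminal ring free of oxygen. A plain phenyl group or a pyridyl group at this place would help to separate those two readings.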